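Nitro to Amino Exchange in Two Vinyl Sulfone Series

The source may hold more compounds than are shown below. What is called first, only, known or untested is meant among the compounds shown, and "the series" means these compounds.

The measured compounds and their values in a functional assay on MDA-MB-468 cells (Homo sapiens) for cytotoxicity, read by MTT assay, with a stated time of 72 h; a lower number here means a stronger inhibitor of growth, a higher number a weaker inhibitor of growth:
compound 1, `COc1ccc(CS(=O)(=O)/C=C/c2ccc(OC)c(OC)c2OC)cc1[N+](=O)[O-]`, gives 21900 nM;
compound 2, `COc1cc(/C=C/S(=O)(=O)Cc2ccc(OC)c([N+](=O)[O-])c2)cc(OC)c1`, gives 16500 nM;
compound 3, `COc1ccc(CS(=O)(=O)/C=C/c2ccc(OC)c(OC)c2OC)cc1N`, gives 3480 nM.

Compounds 1 and 3 share a core and differ at a single point: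

amino in place of nitro on an aromatic carbon

This change gave a 6.3-fold lower number from compound 1 to compound 3 (0.80 log units; beyond the scatter). Compound 2 carries a different core; how the core of compound 2 differs from that of compound 1 is not broken down here. In this assay compound 2 and compound 1 lie within the scatter of each other, so no order between them is claimed.

Compound 4, `COc1cc(/C=C/S(=O)(=O)Cc2ccc(OC)c(N)c2)cc(OC)c1`, is not yet measured. It differs from compound 2 in the following way:

amino in place of nitro on an aromatic carbon

This is the same change as that from compound 1 to compound 3, at a place described in the same words. On the strength of that one precedent, the step from compound 2 to compound 4 in this assay is expected to be about a 5.9-fold lower number from compound 2 to compound 4 (0.77 log units; beyond the scatter). Going by the values given here, compound 4 is therefore estimated at 2800 nM, with a range of 1100 nM to 7500 nM, resting on the single earlier step and the value of compound 2.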

Compound 4, concentration for 50% growth inhibition: 520 nM
The estimate for compound 4 lay 5.4-fold (0.73 log units) above the measured number; measured number outside the range, below it.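

In this assay, amino in place of nitro on an aromatic carbon gave a 32-fold lower number from compound 2 to compound 4 (1.50 log units; beyond the scatter). The direction of the step therefore carried over from the core of compound 1 to the core of compound 2, while its size did not: the same change on two cores in this assay, a 6.3-fold lower number (0.80 log units; beyond the scatter) from compound 1 to compound 3 and a 32-fold lower number (1.50 log units; beyond the scatter) from compound 2 to compound 4, 5.0-fold (0.70 log units) apart, beyond the scatter of two such steps With only these two pairs, the result shows that a step measured on one core does not fix the size of the same step on another core in this series, but it does not show which difference between the two cores goes with the gap, nor whether the direction would hold on a third core.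

The compounds shown leave open whether another nitrogen group, such as methylamino, dimethylamino or acetamido, would compare with amino at this place on either core. They also leave open how the step would behave on a core carrying hydroxy groups in place of the methoxy groups on the ring of the vinyl part.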